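Swapping a bromine for a nitro group on the benzyl ring

A few compounds are considered here, and "the series" means these few. Any claim that something is new, unique, unknown or untested is made for them only; others in the source may bear on it.

Three compounds share one core and differ only in the ring attached to a saturated chain carbon bound to a sulfur. In a functional assay on HCT-116 cells (Homo sapiens) for inhibition, read by MTT assay, with a stated time of 48 h (on this read-out lower numbers stand for stronger inhibition and higher numbers for weaker inhibition), compound 1 `Brc1ccccc1CSc1nnc(-c2ccncc2)n1-c1ccccc1` gives 20200 nM, compound 2 `Clc1cccc(CSc2nnc(-c3ccncc3)n2-c2ccccc2)c1` gives 9820 nM, and compound 3 `Brc1ccc(CSc2nnc(-c3ccncc3)n2-c2ccccc2)cc1` gives 11100 nM. Compound 3 holds the second-highest of the three numbers, yet its gaps to the other two are small: a 1.1-fold higher number from compound 2 to compound 3 (0.05 log units; within the scatter) and a 1.8-fold lower number from compound 1 to compound 3 (0.26 log units; within the scatter), so on this assay the three cannot really be told apart. Among the measured compounds shown here, the only step that reaches beyond the scatter, a 2.1-fold lower number from compound 1 to compound 2 (0.31 log units; beyond the scatter), is still modest.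

Compound 4 `O=[N+]([O-])c1ccccc1CSc1nnc(-c2ccncc2)n1-c1ccccc1` has not yet been measured; it differs from compound 3 in one place: 2-nitrophenyl in place of 4-bromophenyl on a saturated chain carbon bound to a sulfur. For the measured compounds named here, no measured compound carries a nitro group, so the closest guides are the ring swaps already seen, namely a 1.8-fold lower number from compound 1 to compound 3 (0.26 log units; within the scatter) and a 1.1-fold higher number from compound 2 to compound 3 (0.05 log units; within the scatter), both of which left the number within the scatter. On that basis the change to compound 4 is expected to move this assay little, and the estimated step is a 1.1-fold higher number from compound 3 to compound 4 (0.03 log units; within the scatter). Compound 4 is therefore estimated at 12000 nM in this assay, with an expected range from 5000 nM to 30000 nM.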

Compound 4, half-maximal inhibitory concentration: > 50000 nM
Compound 4: only a limit was reported; the forecaster's own chance of this, stated with the estimate: 5%; at least 4.1-fold (0.61 log units) between middle value and limit.
By their numbers in this assay, from the lowest: compounds 2, 3 and 1 (each within the scatter of the next, the first and the last beyond it). At a limit, above all of these: compound 4.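

Compound 4 gives only a limit, not a number, in this assay: the limit of > 50000 nM in this assay, at which 1 of the 4 values shown sits. The most direct comparison is with compound 1, since the two differ only in nitro in place of bromo on an aromatic carbon, and that single swap gives an at least 2.4-fold higher number from compound 1 to compound 4 (0.39 log units; beyond the scatter). The steps from the other two compounds, an at least 4.5-fold higher number from compound 3 to compound 4 (0.65 log units; beyond the scatter) and an at least 5.0-fold higher number from compound 2 to compound 4 (0.70 log units; beyond the scatter), also lie beyond the scatter, so the ring on this saturated chain carbon bound to a sulfur can shift the read-out clearly, which the modest differences among compounds 1, 2 and 3 did not show.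

With a single nitro compound, which ends at a limit, the true size of these steps stays unknown, and so does whether the loss belongs to the nitro group itself or to where it sits on the ring, as no 3-nitrophenyl or 4-nitrophenyl partner is shown. Also open, from the compounds shown here alone, is how an amine or a methoxy group on the same aromatic carbon would read in this assay, which would show whether the weaker result is confined to nitro.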